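This account rests on a few compounds, and the source may have more. Where it says the series, first, only, none or still open, it means among the compounds named here.

Going by the values given here, compound 1, `COc1cc(-c2cc(/C=C/C(=O)c3ccc(N)cc3)[nH]n2)cc(OC)c1OC`, is the only member of this pair with a number of its own: in a functional assay on HCT-116 cells (Homo sapiens) for inhibition, read by sulforhodamine B assay, with a stated time of 48 h (a lower number here means that less compound is tolerated, a higher number that more compound is tolerated), compound 1 gives 6190 nM. Compound 2, `COc1cc(-c2cc(/C=C/C(=O)c3ccc(Cl)c(Cl)c3)[nH]n2)cc(OC)c1OC`, reaches only a limit of this assay, recorded as > 100000 nM. Among the compounds with values here, the single measured step in the set, an at least 16-fold higher number from compound 1 to compound 2 (1.20 log units; beyond the scatter), is therefore known only as a lower bound because the limit of > 100000 nM in this assay, at which 1 of the 2 values shown sits, sits at the end of that step rather than a number. Compound 3, `COc1ccc(C(=O)/C=C/c2cc(-c3cc(OC)c(OC)c(OC)c3)n[nH]2)cc1`, is not yet measured and differs from compound 2 in one place: 4-methoxyphenyl in place of 3,4-dichlorophenyl on a carbonyl carbon. Within the data shown here, the one step that bears on this change is the exchange of the aryl group on the same carbonyl carbon between compound 1 and compound 2, and it was large, so a change of the same kind in the other direction is expected to move this assay by a considerable amount, downward from the limit, while the aminophenyl value of compound 1 need not be reached. Compound 3 is therefore expected to give about 25000 nM, within a range from 6000 nM to 100000 nM. That estimate implies a step of an at least 4.0-fold lower number from compound 2 to compound 3 (0.60 log units; beyond the scatter), with a real chance that only a limit is returned.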

Compound 3, concentration lethal to 50% of the cells: > 100000 nM
Compound 3 gave a limit, no number; the forecaster's own chance of this, stated with the estimate: 35%; at least 4.0-fold (0.60 log units) between middle value and limit.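

In this assay, compound 3 carries a limit, > 100000 nM, and not a number. Methoxy in place of amino on an aromatic carbon gives an at least 16-fold higher number from compound 1 to compound 3 (1.20 log units; beyond the scatter), so a second group in place of 4-aminophenyl on the carbonyl carbon ends at the limit, as 3,4-dichlorophenyl did, and of the three compounds shown only compound 1 has a number of its own. The two limits leave the step between compound 2 and compound 3 unreadable, so neither 3,4-dichlorophenyl nor 4-methoxyphenyl can be placed ahead of the other, and the set now meets this limit twice: the limit of > 100000 nM in this assay, at which 2 of the 3 values shown sit.

On these data alone, what stays open is whether a number in this assay depends on the amino group itself, or whether a hydroxyl group, a dimethylamino group or an aminomethyl group on the aromatic carbon that holds it in compound 1 would also give one. How far compound 2 and compound 3 each lie from the limit also remains unknown, so the size of the difference between these two groups cannot be told from the compounds shown.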